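This account rests on a few compounds, and the source may have more. Where it says the series, first, only, none or still open, it means among the compounds named here.

Measured in a functional assay on A549 cells (Homo sapiens) for cytotoxicity, read by resazurin assay, with a stated time of 48 h; a higher number here means a weaker inhibitor, a lower number a stronger inhibitor:
- Compound 1 `C=C(C)[C@@H]1CC=C(CN(OC)C2OC[C@@H](O)[C@H](O)[C@H]2O)CC1`: 202000 nM
- Compound 2 `C=C(C)[C@@H]1CC=C(CN(OC)C2O[C@H](CN=[N+]=[N-])[C@@H](O)[C@H](O)[C@H]2O)CC1`: 163000 nM

These two values lie within the scatter of each other, so compound 2 stands level with compound 1. Compound 3 `C=CCOC(=O)NC[C@H]1OC(N(CC2=CC[C@@H](C(=C)C)CC2)OC)[C@H](O)[C@@H](O)[C@@H]1O` has (allyloxycarbonyl)amino in place of azido on a saturated chain carbon bound to a saturated ring carbon. Among the measured compounds shown here, only one measured step bears on this, and only loosely, since it brought in the azidomethyl group itself: a 1.2-fold lower number from compound 1 to compound 2 (0.09 log units; within the scatter). That step stays within the scatter, and no step beyond the scatter is expected in this assay. The estimated step is a 1.1-fold lower number from compound 2 to compound 3 (0.04 log units; within the scatter). Compound 3 is expected at 150000 nM, with an estimated range of 60000 nM to 300000 nM.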

Compound 3, half-maximal inhibitory concentration: 140000 nM
For compound 3 the middle estimate is 1.1-fold (0.03 log units) above the measured one; the measured number falls inside the stated range.
By their numbers in this assay, from the lowest: compounds 3, 2 and 1 (each within the scatter of the next).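

In this assay, putting (allyloxycarbonyl)amino in place of azido on this saturated chain carbon gives a 1.2-fold lower number from compound 2 to compound 3 (0.07 log units; within the scatter) and thus shows that a group of 7 heavy atoms, carrying a hydrogen-bond donor, leaves the reading within the scatter. Measured against the hydrogen of compound 1, the whole ((allyloxycarbonyl)amino)methyl group gives a 1.4-fold lower number from compound 1 to compound 3 (0.16 log units; within the scatter) and does not separate the two compounds either. No supporting measurement explains these results. As far as these compounds go, whether a free amine or a carboxylic acid at this place would move the number beyond the scatter remains open.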